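This account rests on a few compounds, and the source may have more. Where it says the series, first, only, none or still open, it means among the compounds named here.

Measured compounds:
- compound 1, `CC(C)c1ccc(C2CN(C)Cc3c(N)cccc32)cc1`, in a functional assay on the whole organism for inhibition of sodium-dependent dopamine transporter (Mus musculus) (a higher number here means that more compound is needed for the effect, a lower number that less compound is needed), compound 1 gives about 65 mg/kg
- compound 2, `CN1Cc2c(NC(=O)OCc3ccccc3)cccc2C(c2ccccc2)C1`, in this assay compound 2 gives 25 mg/kg

Among the compounds with values here, of the two numbers known, compound 2 has the lower one, so less of it is needed for the half-maximal effect than of compound 1; the gap between the two lies beyond the usual scatter of repeated measurements. The next compound, compound 3 `CCCCNCCC(=O)Nc1cccc2c1CN(C)CC2c1ccccc1`, keeps the whole core of compound 2 and differs from it in one place: 2-(butylamino)ethyl in place of benzyloxy on a carbonyl carbon. The ring-bearing group is thus exchanged for an open chain that carries a hydrogen-bond donor of its own. Within the data shown here, no measured pair of compounds shows a change of this kind, and compounds 1 and 2 differ from each other at more than one place, so their comparison says nothing about it. The expected step, a 1.4-fold higher number from compound 2 to compound 3 (0.15 log units; within the scatter), is therefore a cautious one: a slight rise in the number, within or just beyond the scatter, with wide uncertainty either way. For compound 3 the estimate in this assay is 35 mg/kg, with a range from 12 mg/kg to 100 mg/kg.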

Compound 3, dose for half-maximal effect: > 60 mg/kg
Compound 3: a limit, no number; the forecaster's own chance of this, stated with the estimate: 10%; middle value at least 1.7-fold (0.23 log units) away from the limit.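

In this assay, compound 3 gives > 60 mg/kg, which is a limit of the assay and not a number. Even so, the change can be read in one direction, as an at least 2.4-fold higher number from compound 2 to compound 3 (0.38 log units; beyond the scatter), and this is the first exchange at this place on the carbonyl carbon that can be read at all: what sits here matters, and putting 2-(butylamino)ethyl in place of benzyloxy means that more compound is needed for the effect in the whole animal. How much more stays unknown, and the record offers only a floor for it: the limit of > 60 mg/kg in this assay, at which 1 of the 3 values shown sits.

The change removes a six-membered aromatic ring and brings in an open chain with a hydrogen-bond donor in a single step, so the compounds shown cannot tell whether the higher number goes with the ring leaving or with the chain entering. As far as these compounds go, a plain butyl chain or a benzylamino group on the same carbonyl carbon would separate those two parts of the change, and how either would behave remains open.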